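The source may hold more compounds than are shown below. What is called first, only, known or untested is meant among the compounds shown, and "the series" means these compounds.

Measured so far in a functional assay on HCC1806 cells (Homo sapiens) for inhibition, read by sulforhodamine B assay, tested at 10 uM; on this read-out lower numbers stand for less inhibition and higher numbers for more inhibition at the one concentration tested (going by the name of the read-out):

compound 1, `CN(C)c1ccc(C2CC(c3ccc(-n4ccnc4)cc3)=NN2)cc1`, gives -20.9%
compound 2, `CN1CCN(c2ccc(C3=NN(C(=O)c4ccc(C(F)(F)F)cc4)C(c4ccc(N(C)C)cc4)C3)cc2)CC1`, gives 84.1%
compound 3, `CN1CCN(c2ccc(C3=NN(S(=O)(=O)c4ccc(C(F)(F)F)cc4)C(c4ccc(N(C)C)cc4)C3)cc2)CC1`, gives 27%

Compound 2 stands highest of these three numbers. Its nearest neighbour is compound 3, which lies well below it, beyond the usual scatter of this assay; compound 1 lies furthest away, also beyond the scatter. The number of compound 2 is thus the highest of the three measured compounds.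

The unmeasured compound 4, `CN1CCN(c2ccc(C3=NN(S(=O)(=O)c4ccc(C#N)cc4)C(c4ccc(N(C)C)cc4)C3)cc2)CC1`, differs from compound 2 in a single place, on an amine nitrogen in a ring: (4-cyanophenyl)sulfonyl in place of (4-(trifluoromethyl)phenyl)carbonyl on an amine nitrogen in a ring. Compound 4 shares the sulfonyl link with compound 3 rather than the carbonyl link of compound 2, and compound 3 gives 27% in this assay. Going by the values given here, no step between measured compounds covers exactly this change, so the expectation rests on what compounds 2 and 3 show. A large downward step is expected in this assay from compound 2 to compound 4, beyond the scatter, estimated at a number 54.1 percentage points lower from compound 2 to compound 4 (beyond the scatter). Compound 4 is therefore expected to give about 30%, most likely between 5% and 60%.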

Compound 4, a percentage reported as inhibition, at one concentration (the size of the read-out at that concentration, not a potency): 99.8%
Beside the measured number, compound 4's estimate is 69.8 percentage points below it, outside the stated range (above it).
By their numbers in this assay, from the lowest: compound 1; then compound 3; then compound 2; then compound 4.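

In this assay the sulfonyl link on the amine nitrogen in a ring does not by itself keep the number low: with that link in place, cyano in place of trifluoromethyl on an aromatic carbon gives a large rise (a number 72.8 percentage points higher from compound 3 to compound 4 (beyond the scatter)). The group on that aromatic carbon therefore matters greatly here, and the full exchange of (4-(trifluoromethyl)phenyl)carbonyl for (4-cyanophenyl)sulfonyl gives a modest rise overall (a number 15.7 percentage points higher from compound 2 to compound 4 (beyond the scatter)). Nothing available explains why these groups differ in this way.

Still open, on these data alone, is whether cyano would raise the number in the same way with the carbonyl link in place of the sulfonyl link. Also open, as far as these compounds go, is how a methoxy group, an amine or a carboxylic acid on that aromatic carbon would compare with cyano and trifluoromethyl.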